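The source may hold more compounds than are shown below. What is called first, only, known or untested is meant among the compounds shown, and "the series" means these compounds.

Measured compounds:
compound 1, `COc1cc(C(=O)N2CCC(O)C(C)C2)cc2nc(NCc3cncc(Cl)c3)oc12`, 7200 nM
compound 2, `COc1cc(C(=O)N2CCC(O)C(C)C2)cc2nc(N[C@@H](C)c3cccc(Cl)c3)oc12`, 5100 nM

Both were tested in an assay on isolated protein for inhibition of thyroid hormone receptor beta (Homo sapiens), read by fluorescence, with a stated time of 30 min; on this read-out higher numbers stand for weaker inhibition and lower numbers for stronger inhibition. Compound 2 gives the lower of the two numbers, but the step of a 1.4-fold lower number from compound 1 to compound 2 (0.15 log units; within the scatter) is within the scatter, so no order between compound 1 and compound 2 can be claimed.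

Compound 3, `COc1cc(C(=O)N2CCC(O)C(C)C2)cc2nc(N[C@H](C)c3cccc(Cl)c3)oc12`, is not yet measured. It differs from compound 2 only in the two compounds have the same atoms and bonds; at least one stereo element is drawn with a configuration in one of them and without one in the other: 1 of 3 stereo elements differ; a stereocentre at a saturated chain carbon is drawn S in compound 2 and R in compound 3. Within the data shown here, the one measured step, a 1.4-fold lower number from compound 1 to compound 2 (0.15 log units; within the scatter), concerns the exchange of the group on the ring nitrogen and says nothing about the drawn configuration at that chain carbon; no measured pair differs at this stereocentre. The direction of the step to compound 3 therefore cannot be read from the data, and a change in either direction, or none beyond the scatter, remains possible. For compound 3 the expected step is a 1.8-fold higher number from compound 2 to compound 3 (0.25 log units; within the scatter), and the estimated value is 9000 nM with a range from 3000 nM to 30000 nM.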

Compound 3, half-maximal inhibitory concentration: 48 nM
Compound 3: middle estimate off by 190-fold (2.27 log units), on the high side; measured number below the stated range.
By their numbers in this assay, from the lowest: compound 3; then compounds 2 and 1 (each within the scatter of the next).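

In this assay, the configuration at the saturated chain carbon decides the outcome, with no atom or bond changed: a 110-fold lower number from compound 2 to compound 3 (2.03 log units; beyond the scatter) is a large step, with the R form giving the lower number. The exchange of (5-chloropyridin-3-yl)methyl for 1-(3-chlorophenyl)ethyl on the nitrogen, which looked flat with the S form, now reads as a 150-fold lower number from compound 1 to compound 3 (2.18 log units; beyond the scatter), so among these compounds the new group gives a clear gain only when drawn R. One point limits how far the step can be read as a clean contrast of two configurations: the fact that one of compounds 2 and 3 is drawn with a defined configuration and the other without, at the place where they differ.

On these data alone, how the other stereo elements affect the number stays open. As far as these compounds go, it is also open whether the preference for the R form persists when an ethyl group replaces the methyl at this carbon, or a trifluoromethyl group replaces the chlorine on the phenyl ring.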